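The compounds below may be only part of what the source reports. "The series", "measured", "known", "first", "only" and "open" are said of these compounds alone.

In an ADME assay on HEK293 cells (Homo sapiens) for cytotoxicity, with a stated time of 72 h (on this read-out lower numbers stand for an effect already at smaller amounts and higher numbers for an effect only at larger amounts of compound), compound 1 `Cc1cc(NC(=O)Nc2cccc(F)c2)c2ccccc2n1` gives > 25000 nM, which is a limit of the assay and not a number. Compound 2 `Cc1cc(NC(=O)Nc2ccccc2F)c2ccccc2n1` gives > 25000 nM, which is also a limit. Going by the values given here, compound 2 therefore stands with its only neighbour, at the limit of > 25000 nM in this assay, at which 2 of the 2 values shown sit. Compound 3 `Cc1cc(NC(=O)Nc2cc(F)ccc2F)c2ccccc2n1` differs from compound 2 by one small change: fluoro in place of hydrogen on an aromatic carbon. Among the compounds with values here, only one measured step bears on this change, a step that the two limits leave unreadable from compound 1 to compound 2. That step swaps one fluorinated ring for another and offers no size to carry forward, so the evidence points to no clear step in either direction in this assay. The expected change is a step that the limit leaves unreadable from compound 2 to compound 3. For compound 3 the estimated value is 30000 nM, with an expected range of 14000 nM to 60000 nM, and the assay may well report only a limit again.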

Compound 3, half-maximal effective concentration: 12000 nM
Compound 3: the middle estimate sits 2.5-fold (0.40 log units) above what was measured; the measured number lies below the stated range.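

In this assay, going by these compounds alone, placing a fluoro group on this aromatic carbon, meta to a large group and para to a fluoro group, gives the first change that can be read, with the effect on the cells appearing at smaller amounts of compound: an at least 2.0-fold lower number from compound 2 to compound 3 (0.31 log units; beyond the scatter). Within the data shown here, the comparison with the compound carrying its single fluoro group elsewhere on the ring points the same way, showing an at least 2.0-fold lower number from compound 1 to compound 3 (0.31 log units; beyond the scatter). The earlier pair could show no such change, and its one step could not be read: the limit of > 25000 nM in this assay, at which 2 of the 3 values shown sit.

On these data alone, the exact size of both steps stays open, since each is read against a limit and not a number. Also open, as far as these compounds go, is whether this shift belongs to fluoro alone, or whether a chloro group, a methoxy group or an amine at the same carbon would give a similar one.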